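The source may hold more compounds than are shown below. What is called first, only, known or untested is meant among the compounds shown, and "the series" means these compounds.

Measured so far in a functional assay on RD cells (Homo sapiens) for inhibition, read by luminescence and ATP content, with a stated time of 72 h (a lower number here means that less compound is tolerated, a higher number that more compound is tolerated), are three compounds, each value a limit:
- compound 1 `CCCCc1ccc(-c2ccc3ncc(C(=O)OCC)cc3c2)cc1` with > 7400 nM as a limit
- compound 2 `CCCCc1ccc(-c2ccc3ncc(-c4noc(C(F)(F)F)n4)cc3c2)cc1` with > 7400 nM as a limit
- compound 3 `CCCCc1ccc(-c2ccc3ncc(-c4noc(CC)n4)cc3c2)cc1` with > 7400 nM as a limit

Compound 3 stands at > 7400 nM and this is a limit, not a number. Among the measured compounds shown here, the series so far shows only the limit of > 7400 nM in this assay, at which 3 of the 3 values shown sit, and no compound in it can be ranked.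

Compound 4 `CCc1nc(-c2cnc3ccc(-c4ccc(OC)cc4)cc3c2)no1` differs from compound 3 in one place. The change is methoxy in place of butyl on an aromatic carbon and in words it is methoxy in place of butyl on an aromatic carbon, para to a large group.

The measured steps are a step that the two limits leave unreadable from compound 1 to compound 2 and a step that the two limits leave unreadable from compound 1 to compound 3 and a step that the two limits leave unreadable from compound 2 to compound 3 and none has a readable size. All three keep butyl in place and alter another group, so none tests this change directly.

No step beyond the scatter is expected, and another limit is the likeliest report. This expectation rests on compound 3 at > 7400 nM as its only anchor. The expected step is a step that the limit leaves unreadable from compound 3 to compound 4 and it is only a rough estimate. In this assay the estimate for compound 4 is 10000 nM with an expected range from 4000 nM to 25000 nM as a working guess.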

Compound 4, half-maximal cytotoxic concentration: > 2500 nM
Compound 4 gave a limit, no number (the forecaster's own chance of this, stated with the estimate: 85%); the middle value lies beyond the limit too.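

No step can be read between compound 3 and compound 4: in this assay both are reported only as limits, not numbers, and the effect of methoxy in place of butyl stays unsized. The compounds shown leave open at what concentration any of compound 1, compound 2, compound 3 or compound 4 reaches half-maximal cytotoxicity, and how they rank.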